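A hydroxy group added to the phenyl of compound 2

The source may hold more compounds than are shown below. What is called first, only, known or untested is meant among the compounds shown, and "the series" means these compounds.

Three compounds share a core carrying a hydroxyphenyl on a ring carbon and an aryl on the ring nitrogen. Compound 1 `CC(C)(C)C1=NN(c2cccc(F)c2)C(c2ccc(O)cc2)C1`, with a tert-butyl group and a fluorophenyl, gives 19.3% in an assay on isolated protein for inhibition of protein kinase C iota type (Homo sapiens), tested at 20 uM; a higher number here means more inhibition at the concentration tested (going by the name of the read-out), a lower number less inhibition. Compound 2 `Oc1ccc(C2CC(c3ccccc3)=NN2c2ccc(Cl)cc2)cc1`, with a phenyl and a 4-chlorophenyl, gives 31.6% in this assay. Compound 3 `Oc1ccc(C2CC(c3ccccc3)=NN2c2cccc(Cl)c2)cc1`, with the chlorine moved, gives 45.5% in this assay. Going by the values given here, compound 2 thus stands second highest of the three: compound 1 lies beyond the scatter below it, and the only single change on record, a number 13.9 percentage points higher from compound 2 to compound 3 (beyond the scatter), lifts the number beyond the scatter.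

Compound 4 `Oc1ccc(C2CC(c3ccccc3O)=NN2c2ccc(Cl)cc2)cc1` differs from compound 2 in one place: hydroxy in place of hydrogen on an aromatic carbon. Among the compounds with values here, no measured step touches this phenyl; the one known step concerns the chlorophenyl on the nitrogen and says nothing about the ring that is changed here. Within the data shown here, with no step bearing on it, the expectation is a number close to that of compound 2, and any movement within the scatter, so compound 4 is estimated to come out at 33% in this assay, between 13% and 53%. That estimate means a step of a number 1.4 percentage points higher from compound 2 to compound 4 (within the scatter), expected to stay within the scatter.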

Compound 4, a percentage reported as inhibition, at one concentration (the size of the read-out at that concentration, not a potency): 13.4%
Estimate against measurement, compound 4: 19.6 percentage points above; low and high end bracket the measured number.
By their numbers in this assay, from the lowest: compounds 4 and 1 (each within the scatter of the next); then compound 2; then compound 3.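

Going by these compounds alone, the change from phenyl to 2-hydroxyphenyl gives a number 18.2 percentage points lower from compound 2 to compound 4 (beyond the scatter) in this assay, so this ring, which no earlier step had touched, is not a silent part of the molecule. Within the data shown here, until now the only single change on record lay on the chlorophenyl on the ring nitrogen; here a second aryl ring also moves the number, and adding a hydroxy ortho to a large group goes with less inhibition at the concentration tested, not more. Nothing measured on these compounds gives a reason for this fall.

The compounds shown leave open whether the fall belongs to the hydroxy group as such or to this place on the ring, and how a methoxy group or an amine at the same place would compare with compound 2. Among these compounds, they also leave open whether the same hydroxy would lower the number by a similar amount on the 3-chlorophenyl of compound 3, the highest of the series so far.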